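Notes on the step from compound 2 to compound 3

A few compounds are considered here, and "the series" means these few. Any claim that something is new, unique, unknown or untested is made for them only; others in the source may bear on it.

Values so far from a physicochemical assay for lipophilicity, read by mass spectrometry; a lower number here means a more polar compound, a higher number a more lipophilic compound
- compound 1 `COc1cc2c(cc1OC)C(=O)C(C(=O)Nc1ccccc1)C2` gives 2.2
- compound 2 `COc1cc2c(cc1OC)C(=O)C(C(=O)Nc1cccc(Br)c1)C2` gives 3.03

Compound 2 stands highest of the two at 3.03 with compound 1 as its nearest neighbour. The next structure is compound 3 `COc1cc2c(cc1OC)C(=O)C(C(=O)Nc1ccccc1C)C2` with 2-methylphenyl in place of 3-bromophenyl on an amide-type nitrogen as its difference, 2-methylphenyl in place of 3-bromophenyl on an amide-type nitrogen. Within the data shown here, only one measured step bears on this change, a number 0.83 log units higher from compound 1 to compound 2 (beyond the scatter) for bromo in place of hydrogen on an aromatic carbon. Among the measured compounds shown here, the bromo leaves here, so that step is the guide to what may be lost, but no measured compound carries 2-methylphenyl. In this assay a modest step downward is therefore expected, probably smaller than the measured one. The expected change is a number 0.48 log units lower from compound 2 to compound 3 (beyond the scatter) in this estimate. Compound 3 is estimated at 2.55 within an expected range of 2.2 to 2.9 for this measurement.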

Compound 3, partition coefficient: 2.69
The estimate for compound 3 lay 0.14 log units below the measured number; low and high end bracket the measured number.
By their numbers in this assay, from the lowest: compound 1; then compound 3; then compound 2.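

In this assay, 2-methylphenyl in place of 3-bromophenyl on the amide-type nitrogen gives a number 0.34 log units lower from compound 2 to compound 3 (beyond the scatter), so losing the bromo does not return the number to that of compound 1. The methyl group gives a number 0.49 log units higher from compound 1 to compound 3 (beyond the scatter), which makes this the second substituent on the aromatic ring of the anilide to raise the number, with neither compound shown going against that direction, and the rise is smaller than a number 0.83 log units higher from compound 1 to compound 2 (beyond the scatter). No measurement on hand accounts for the size of either rise.

Since 3-bromophenyl and 2-methylphenyl differ in both the group and its numbered place, the compounds shown do not separate these two contributions. Still open, from the compounds shown here alone, is how a carboxylic acid or an amine on that aromatic ring would read in this assay.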